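The source may report more compounds than this note shows. Statements on the series, on what has been measured and on what is new or still open speak of the compounds shown alone.

Measured so far:
compound 1 `Nc1scc(CN2CCN(c3ccc(Cl)cc3Cl)CC2)c1C(=O)c1ccc(Cl)cc1` gives -11%
compound 2 `Nc1scc(CN2CCN(c3cccc4ccccc34)CC2)c1C(=O)c1ccc(Cl)cc1` gives 0%

In a functional assay on CHO cells with adenosine receptor A1 (Homo sapiens) as the target, read by cAMP accumulation and immunoassay, with a stated time of 6 min, tested at 0.1 uM (on this read-out higher numbers stand for a weaker effect at the one concentration tested and lower numbers for a stronger effect), compound 2 stands highest of the two numbers; its nearest neighbour is compound 1, and the step of a number 11 percentage points higher from compound 1 to compound 2 (beyond the scatter) lies beyond the scatter. Compound 3 `Nc1scc(CN2CCN(c3cccc(Cl)c3)CC2)c1C(=O)c1ccc(Cl)cc1` has not been measured. Its difference from compound 2 is 3-chlorophenyl in place of naphthalen-1-yl on an amine nitrogen in a ring. Among the measured compounds shown here, the only step that bears on it is the one from compound 1 to compound 2, which also swaps a chlorine-bearing phenyl for naphthalen-1-yl on the same ring nitrogen; here the swap runs the other way, so a modest fall is expected, a number 6 percentage points lower from compound 2 to compound 3 (within the scatter). Compound 3 is expected to give -6%, between -20% and 8%.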

Compound 3, a percentage reported as activity, at one concentration (the size of the read-out at that concentration, not a potency): -20%
Beside the measured number, compound 3's estimate is 14 percentage points above it; measured number inside the range.
By their numbers in this assay, from the lowest: compounds 3 and 1 (each within the scatter of the next); then compound 2.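

Swapping naphthalen-1-yl for 3-chlorophenyl on this amine nitrogen in a ring gives a number 20 percentage points lower from compound 2 to compound 3 (beyond the scatter) in this assay, so on this read-out the effect is stronger with one aromatic ring here than with two. Moving from 2,4-dichlorophenyl to 3-chlorophenyl gives a number 9 percentage points lower from compound 1 to compound 3 (within the scatter), so these two chlorinated phenyl groups cannot be told apart in this test. Nothing measured here explains either result. Whether chlorine matters at all remains open, since plain phenyl is not among these compounds. A methoxy group or a methyl group in place of the chlorine is equally untested in what is shown.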